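Extending the amide substituent toward a fluorobenzyl group

The source may hold more compounds than are shown below. What is called first, only, known or untested is meant among the compounds shown, and "the series" means these compounds.

Compound 2 `COc1ccc(OC)c(-c2cc(-c3ccc(C(=O)N(C)C)s3)on2)c1` carries a dimethylamino amide on the shared core. In a functional assay on A549 cells (Homo sapiens) for cytotoxicity, read by XTT assay, with a stated time of 72 h (a lower number here means a stronger inhibitor, a higher number a weaker inhibitor), compound 2 gives > 30000 nM, which is a limit of the assay rather than a number. Compound 1 `CCCN(C)C(=O)c1ccc(-c2cc(-c3cc(OC)ccc3OC)no2)s1` differs from compound 2 only by ethyl in place of hydrogen on a saturated chain carbon bound to an amide-type nitrogen. In this assay compound 1 gives > 30000 nM, again a limit. The step that the two limits leave unreadable from compound 1 to compound 2 therefore cannot be read. Compound 3 `COc1ccc(CN(C)C(=O)c2ccc(-c3cc(C4=CC(=O)C=CC4=O)no3)s2)cc1` also carries an aromatic ring on a saturated chain carbon bound to an amide-type nitrogen, and differs from compound 2 in a second place too. In this assay compound 3 gives > 30000 nM, once more a limit. All three values sit at the limit of > 30000 nM in this assay, at which 3 of the 3 values shown sit. Compound 4 `COc1ccc(OC)c(-c2cc(-c3ccc(C(=O)N(C)Cc4ccc(F)cc4)s3)on2)c1` is the unmeasured partner of compound 2: 4-fluorophenyl in place of hydrogen on a saturated chain carbon bound to an amide-type nitrogen. Among the compounds with values here, no measured step follows this change, and compound 3 shows that a benzyl-type amide can likewise sit at the limit. The expectation is that compound 4 stays near the limit, with an estimated step that the limit leaves unreadable from compound 2 to compound 4. Compound 4 is thus estimated at 40000 nM, within 15000 nM to 150000 nM.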

Compound 4, half-maximal inhibitory concentration: > 30000 nM
Compound 4: only a limit was reported; the forecaster's own chance of this, stated with the estimate: 75%; the middle value is on the limit's open side.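

In this assay compound 4 gives > 30000 nM, which is a limit and not a number. The steps to compound 4 from compound 1 and compound 2 therefore cannot be read. The compounds shown leave open whether any amide substituent here would give a readable number: the limit of > 30000 nM in this assay, at which 4 of the 4 values shown sit.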